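The source may hold more compounds than are shown below. What is called first, only, known or untested is meant among the compounds shown, and "the series" means these compounds.

In a functional assay on HT-29 cells (Homo sapiens) for inhibition, read by sulforhodamine B assay, with a stated time of 72 h (on this read-out lower numbers stand for stronger inhibition and higher numbers for weaker inhibition), compound 1 (`COc1ccc(C2C(O)C(=O)N2c2cc(OC)c(OC)c(OC)c2)cc1`) gives 12 nM as its result, and compound 2 (`CCSc1ccc(C2C(O)C(=O)N2c2cc(OC)c(OC)c(OC)c2)cc1`) sits level with it, giving 12 nM as well. Compound 3 (`C=CC1C(=O)N(c2cc(OC)c(OC)c(OC)c2)C1c1ccc(OC)cc1`) is still unmeasured. It keeps the core of compound 1 but carries vinyl in place of hydroxy on a saturated ring carbon. Among the compounds with values here, the only measured step (no change at the digits printed from compound 1 to compound 2 (within the scatter)) puts ethylsulfanyl in place of methoxy on an aromatic carbon, a different place, so it bears on this change only loosely. Within the data shown here, no measured compound varies the hydroxy, so the data offer no direction here. In this assay no shift beyond the scatter is expected, though the uncertainty is wide. The expected step (a 1.3-fold higher number from compound 1 to compound 3 (0.10 log units; within the scatter)) is small. Compound 3 is estimated at 15 nM within a range from 4 nM to 70 nM for now.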

Compound 3, half-maximal inhibitory concentration: 10 nM
For compound 3 the middle estimate is 1.5-fold (0.18 log units) above the measured one; measured number inside the range.
By their numbers in this assay, from the lowest: compounds 3, 1 and 2 (each within the scatter of the next).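

In this assay, within the data shown here, the change gives a 1.2-fold lower number from compound 1 to compound 3 (0.08 log units; within the scatter) and so leaves the number in place, which the earlier compounds could not show because neither of them varied this carbon of the four-membered ring. The hydroxy, with its hydrogen-bond donor and acceptor, is therefore not required here for a result at this level: vinyl, with neither of these and with two heavy atoms instead of one, stands level with it. No measurement at hand offers a reason for this outcome.

The compounds shown leave open how much room this position allows, for example whether an amine, a carboxylic acid or a longer chain such as n-butyl would keep the number at this level. They also leave open whether vinyl and ethylsulfanyl would hold up together in one compound.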